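The source may hold more compounds than are shown below. What is called first, only, known or untested is meant among the compounds shown, and "the series" means these compounds.

Half-life in a functional assay on aorta with Voltage-dependent L-type calcium channel subunit alpha-1C (Oryctolagus cuniculus) as the target (a lower number here means that the compound disappears faster, a higher number that the compound lasts longer), is known for two compounds of the shared core. Compound 1 `CO/C(O)=C1\C(C)=NC(C)=C(C(=O)OCCCN2C(=O)c3ccccc3S2(=O)=O)C1c1ccccc1[N+](=O)[O-]` gives 0.0817 h in this assay. Compound 2 `CO/C(O)=C1\C(C)=NC(C)=C(C(=O)OCCCN2C(=O)c3ccccc3S2(=O)=O)C1c1cccc(Cl)c1Cl` gives 0.283 h in this assay, the higher of the two numbers; the single step shown, a 3.5-fold higher number from compound 1 to compound 2 (0.54 log units; beyond the scatter), lies beyond the scatter. Compound 3 `CO/C(O)=C1\C(C)=NC(C)=C(C(=O)OCCCN2C(=O)c3ccccc3S2(=O)=O)C1c1ccccc1Cl` is not yet measured. It differs from compound 2 in one place: hydrogen in place of chloro on an aromatic carbon. Among the compounds with values here, no measured step takes away a lone chloro; the step of a 3.5-fold higher number from compound 1 to compound 2 (0.54 log units; beyond the scatter) exchanges 2-nitrophenyl for 2,3-dichlorophenyl and so bears only indirectly on the move from 2,3-dichlorophenyl to 2-chlorophenyl. That step was modest and the present change is a smaller one, so for compound 3 a step of about a 1.6-fold lower number from compound 2 to compound 3 (0.20 log units; within the scatter) in this assay is expected, a slight decrease that may well sit within the scatter. The estimate for compound 3 in this assay is 0.18 h, with a range from 0.07 h to 0.45 h.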

Compound 3, half-life: 0.0867 h
Compound 3: the middle estimate sits 2.1-fold (0.32 log units) above what was measured; the measured number falls inside the stated range.
By their numbers in this assay, from the lowest: compounds 1 and 3 (each within the scatter of the next); then compound 2.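

In this assay, the chloro ortho to a chloro group and meta to a large group proves to be the part that counts among these three compounds: hydrogen in its place gives a 3.3-fold lower number from compound 2 to compound 3 (0.51 log units; beyond the scatter). Exchanging nitro for chloro on the aromatic carbon gives only a 1.1-fold higher number from compound 1 to compound 3 (0.03 log units; within the scatter), so 2-nitrophenyl and 2-chlorophenyl are not told apart here, and the higher number of compound 2 goes with 2,3-dichlorophenyl, which carries the second chloro. Nothing at hand accounts for the effect of this second chloro.

Open, on these data alone, is whether a methyl, a fluoro or a methoxy group at this place would match chloro. Also open, as far as these compounds go, is whether this chloro would keep the higher number without the other chloro on the ring.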